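A side chain swap from amine to thioether

The source may hold more compounds than are shown below. What is called first, only, known or untested is meant among the compounds shown, and "the series" means these compounds.

Three compounds share one core and differ only in the side chain on the saturated ring. Compound 1 `CCCCCCNC[C@H]1O[C@@H](n2cc(C)c(=O)[nH]c2=O)C[C@@H]1O` gives 180000 nM in an assay on BHK21 (C13) cells (Mesocricetus auratus) for inhibition of thymidine kinase, cytosolic (Cricetulus griseus), using Lineweaver-Burk analysis; a higher number here means a weaker inhibitor, a lower number a stronger inhibitor. Compound 2 `CC(=O)NCCNC[C@H]1O[C@@H](n2cc(C)c(=O)[nH]c2=O)C[C@@H]1O` gives 250000 nM. Compound 3 `CC(=O)N(C)CCN(C)C[C@H]1O[C@@H](n2cc(C)c(=O)[nH]c2=O)C[C@@H]1O` gives 900000 nM. Compound 2 holds the second highest of the three numbers: its gap to compound 1 lies within the scatter, while compound 3 sits beyond it. Compound 4 `Cc1cn([C@H]2C[C@H](O)[C@@H](CSCCO)O2)c(=O)[nH]c1=O` carries (2-hydroxyethyl)sulfanyl in place of (2-acetamidoethyl)amino on a saturated chain carbon bound to a saturated ring carbon. Going by the values given here, the one measured step, a 1.4-fold higher number from compound 1 to compound 2 (0.14 log units; within the scatter), exchanges a group two bonds along the chain from an amine nitrogen and changed little, but no measured pair replaces the amine nitrogen itself with sulfur. The step expected here is therefore modest, a 1.2-fold higher number from compound 2 to compound 4 (0.08 log units; within the scatter). Compound 4 is estimated at 300000 nM, with a range from 80000 nM to 1100000 nM.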

Compound 4, inhibition constant: 800000 nM
The estimate for compound 4 lay 2.7-fold (0.43 log units) below the measured number; measured number inside the range.
By their numbers in this assay, from the lowest: compounds 1 and 2 (each within the scatter of the next); then compounds 4 and 3 (each within the scatter of the next).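

Putting (2-hydroxyethyl)sulfanyl on the saturated chain carbon bound to a saturated ring carbon gives a weaker inhibitor, with a 3.2-fold higher number from compound 2 to compound 4 (0.51 log units; beyond the scatter) when it replaces (2-acetamidoethyl)amino and a 4.4-fold higher number from compound 1 to compound 4 (0.65 log units; beyond the scatter) when it replaces hexylamino. The earlier step, a 1.4-fold higher number from compound 1 to compound 2 (0.14 log units; within the scatter), kept the amine nitrogen and did not move the number beyond the scatter. No measurement here explains the loss.

Each new step changes the whole group, so the sulfur and the chain end cannot be told apart. A (2-hydroxyethyl)amino group would separate the two.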